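A few compounds are considered here, and "the series" means these few. Any claim that something is new, unique, unknown or untested is made for them only; others in the source may bear on it.

Of the compounds shown here, three that share one core have been measured in a functional assay on MCF7 cells (Homo sapiens) for inhibition, read by MTT assay, with a stated time of 24 h; on this read-out higher numbers stand for weaker inhibition and lower numbers for stronger inhibition. Compound 1 `CCOC(=O)C1=Cc2ccccc2OC1(OCc1cn(-c2ccc(F)cc2)nn1)C(F)(F)F` gives 9100 nM, the lowest of the two numbers shown. Compound 3 `CCOC(=O)C1=Cc2ccccc2OC1(OCc1cc(-c2ccc3ccccc3c2)no1)C(F)(F)F` gives 65400 nM in this assay. Compound 2 `CCCCCCCCn1cc(COC2(C(F)(F)F)Oc3ccccc3C=C2C(=O)OCC)nn1` reaches only a limit of the assay in this assay, > 150000 nM, which is a limit rather than a number (the limit of > 150000 nM in this assay, at which 1 of the 3 values shown sits). Among the measured compounds, one pair differs in a single place: an at least 16-fold higher number from compound 1 to compound 2 (1.21 log units; beyond the scatter), with octyl in place of 4-fluorophenyl on an aromatic nitrogen.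

Compound 4 `CCOC(=O)C1=Cc2ccccc2OC1(OCc1cn(CC(=O)Nc2ccc(OC)cc2)nn1)C(F)(F)F` has not yet been measured. It differs from compound 1 in one place: ((4-methoxyphenyl)carbamoyl)methyl in place of 4-fluorophenyl on an aromatic nitrogen. Among the compounds with values here, only one measured step bears on this change, an at least 16-fold higher number from compound 1 to compound 2 (1.21 log units; beyond the scatter), where the same 4-fluorophenyl on the same aromatic nitrogen was exchanged, and the number rose by a large margin. Compound 4 keeps a six-membered aromatic ring within the entering group, whereas compound 2 carried an octyl chain there, so the expected step for compound 4 is a weakening that falls short of what compound 2 showed. The step estimated for compound 4 is a 3.3-fold higher number from compound 1 to compound 4 (0.52 log units; beyond the scatter). The value expected for compound 4 in this assay is 30000 nM, with a range from 8000 nM to 150000 nM.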

Compound 4, half-maximal inhibitory concentration: 28100 nM
Beside the measured number, compound 4's estimate is 1.1-fold (0.03 log units) above it, within the range that was stated.
By their numbers in this assay, from the lowest: compound 1; then compound 4; then compound 3. At a limit, above all of these: compound 2.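

Within the data shown here, until now, the only exchange seen at this aromatic nitrogen was the octyl chain, and the new group shows that replacing 4-fluorophenyl need not cost as much: ((4-methoxyphenyl)carbamoyl)methyl gives a 3.1-fold higher number from compound 1 to compound 4 (0.49 log units; beyond the scatter) in this assay, a real but modest loss that leaves 4-fluorophenyl with the lowest number among the groups tried here. Compounds 2 and 4 both hold a saturated chain carbon on that nitrogen, and what extends from that carbon matters, since (4-methoxyphenyl)carbamoyl in place of heptyl gives an at least 5.3-fold lower number from compound 2 to compound 4 (0.72 log units; beyond the scatter). The true size of that step remains unknown, since compound 2 stands at a limit rather than a number: the limit of > 150000 nM in this assay, at which 1 of the 4 values shown sits.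

The compounds shown do not reveal which part of the new group accounts for its advantage over the heptyl chain, the amide, the methoxy or the aromatic ring, and a plain benzyl group or a (phenylcarbamoyl)methyl group on this nitrogen would help to separate them. They also leave open whether an amine or a carboxylic acid at this place could bring the number below that of compound 1.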